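The source may hold more compounds than are shown below. What is called first, only, known or untested is meant among the compounds shown, and "the series" means these compounds.

Of the compounds shown here, two carrying the same shared core have been measured. Compound 1 `CC(=O)OC[C@H]1O[C@@H](n2cc(CN3C(=O)/C(=C/c4ccccc4)c4ccccc43)nn2)[C@H](OC(C)=O)[C@@H](OC(C)=O)[C@@H]1OC(C)=O` gives 22800 nM in a functional assay on DU-145 cells (Homo sapiens) for cytotoxicity, read by sulforhodamine B assay, with a stated time of 48 h; a higher number here means a weaker inhibitor, a lower number a stronger inhibitor. Compound 2 `CC(=O)OC[C@H]1O[C@@H](n2cc(CN3C(=O)/C(=C\C=C\c4ccccc4)c4ccccc43)nn2)[C@H](OC(C)=O)[C@@H](OC(C)=O)[C@@H]1OC(C)=O` gives 19500 nM in this assay, the lowest of the two numbers, and the number for compound 1 sits within the scatter of it. Compound 3 `CC(=O)OC[C@H]1O[C@@H](n2cc(CN3C(=O)/C(=C/C=C/c4ccccc4)c4ccccc43)nn2)[C@H](OC(C)=O)[C@@H](OC(C)=O)[C@@H]1OC(C)=O` is not yet measured; against compound 2 (the two compounds have the same atoms and bonds and differ only in configuration as drawn: 1 of 7 stereo elements differ; a double bond is drawn Z in compound 2 and E in compound 3), so the atoms and bonds stay the same. Among the measured compounds shown here, no step between measured compounds is available to weigh such a change, so no step beyond the scatter is expected in either direction. Compound 3 is therefore estimated at 20000 nM in this assay, within 8000 nM to 50000 nM, a step of a 1.0-fold higher number from compound 2 to compound 3 (0.01 log units; within the scatter).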

Compound 3, half-maximal inhibitory concentration: 17100 nM
Estimate against measurement, compound 3: 1.2-fold (0.07 log units) above; the measured number falls inside the stated range.
By their numbers in this assay, from the lowest: compounds 3, 2 and 1 (each within the scatter of the next).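

In this assay the drawn geometry of this double bond makes no difference beyond the scatter, with a 1.1-fold lower number from compound 2 to compound 3 (0.06 log units; within the scatter) as the step. This comparison isolates that single feature: the fact that compounds 2 and 3 differ only in the configuration as drawn. The 2-phenylethenyl group in place of phenyl likewise stays within the scatter, with a 1.3-fold lower number from compound 1 to compound 3 (0.12 log units; within the scatter) as the step, so neither the chain nor its geometry separates these compounds here. Going by these compounds, whether an amine or a carboxylic acid in place of the phenyl would move the number beyond the scatter remains open.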